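A few compounds are considered here, and "the series" means these few. Any claim that something is new, unique, unknown or untested is made for them only; others in the source may bear on it.

Measured in a functional assay, read by spectrophotometry, with a stated time of 30 min; a lower number here means a stronger inhibitor, a higher number a weaker inhibitor:
compound 1 `CC(C)(C)c1cc(CCC(=O)NCCC2CCN(Cc3ccccc3)CC2)cc(C(C)(C)C)c1O`: 54500 nM
compound 2 `CC(C)(C)c1cc(/C=C/C(=O)NC2CCN(Cc3ccccc3)CC2)cc(C(C)(C)C)c1O`: 71900 nM
compound 3 `CC(C)(C)c1cc(/C=C/C(=O)NCCC2CCN(Cc3cccc(F)c3)CC2)cc(C(C)(C)C)c1O`: 55200 nM

All three values lie within the scatter of one another. Compound 3 therefore stands level with both compound 1 and compound 2, and no order can be read among the three. No two of these compounds differ in one place only, so the series offers no measured single change to lean on.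

The next compound to be read in this assay is compound 4 `CC(C)(C)c1cc(/C=C/C(=O)NCCC2CCN(Cc3cccc(Cl)c3)CC2)cc(C(C)(C)C)c1O`, which keeps everything in compound 3 except one group: chloro in place of fluoro on an aromatic carbon. This is chloro in place of fluoro on an aromatic carbon, or 3-fluorobenzyl to 3-chlorobenzyl when cut one bond further out. The series holds no direct measurement of this exchange.

The expectation rests on compound 1 at 54500 nM and compound 2 at 71900 nM, both of which differ from compound 3 in more than one place and still fall within the scatter of it. No shift beyond the scatter is expected for this smaller change, in either direction. The expected 1.1-fold lower number from compound 3 to compound 4 (0.04 log units; within the scatter) is estimated to stay within the scatter. The estimate for compound 4 is 50000 nM, with an expected range of 24000 nM to 100000 nM.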

Compound 4, half-maximal inhibitory concentration: 83100 nM
The estimate for compound 4 lay 1.7-fold (0.22 log units) below the measured number; the range from low to high includes it.
By their numbers in this assay, from the lowest: compounds 1, 3, 2 and 4 (each within the scatter of the next).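

In this assay the series now holds its first measured single change, chloro in place of fluoro on an aromatic carbon, and the step reads a 1.5-fold higher number from compound 3 to compound 4 (0.18 log units; within the scatter), so compound 3 and compound 4 stand level. At this place on the ring, meta to a large group, 3-fluorobenzyl and 3-chlorobenzyl cannot be told apart in this read-out, which shows that this exchange of one halogen for another leaves the inhibition within repeat-measurement noise. No measurement among the available data bears on this result, and nothing can be said about what lies behind it.

From the compounds shown here alone, whether an amine, a carboxylic acid or a methoxy group on this same aromatic carbon would move the number beyond the scatter stays open, as does the outcome of placing chloro on the other carbons of that ring. Going by these compounds, the weight of the linking chain and its double bond also stays open, with compound 1 and compound 2 still differing from compound 3 and compound 4 in more than one place.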